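The source may report more compounds than this note shows. Statements on the series, on what has been measured and on what is new or still open speak of the compounds shown alone.

Of the compounds shown here, three have been tested in an ADME assay for permeability; a higher number here means that the compound crosses the layer faster, a lower number that the compound crosses the layer more slowly. Compound 1 `CNC(=O)c1cc(C(=O)N[C@H]2CC[C@H](O)CC2)c([C@@H](C)c2cccc(F)c2)o1` gives 73 nm/s. Compound 2 `CNC(=O)c1cc(C(=O)NC2CC2)n(Cc2ccccc2)n1` returns only a limit of the assay, > 80 nm/s, not a number. Compound 3 `CCNC(=O)c1cc(C(=O)NC)nn1[C@@H](C)c1ccccc1` gives 435 nm/s, the highest of the two actual numbers; the nearest is compound 1, whose number is lower by a gap that lies beyond the usual scatter.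

Compound 4 `CNC(=O)c1cc(C(=O)N[C@H]2[C@@H]3C[C@@H](OC)C[C@@H]32)n([C@@H](C)c2ccccc2)n1` is yet to be measured in this assay. It differs from compound 3 in one place: a group of 8 heavy atoms (7 carbon, 1 oxygen; one three-membered non-aromatic ring of carbon only, one five-membered non-aromatic ring of carbon only) in place of a group of 2 heavy atoms (2 carbon; no ring), on an amide-type nitrogen. Among the compounds with values here, no measured pair shows a step of this kind, so the direction is open. The expectation is a step of a 1.5-fold lower number from compound 3 to compound 4 (0.16 log units; within the scatter), which would stay close to the scatter. Compound 4 is therefore estimated at 300 nm/s, between 120 nm/s and 700 nm/s.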

Compound 4, apparent permeability: 440 nm/s
Beside the measured number, compound 4's estimate is 1.5-fold (0.17 log units) below it, within the range that was stated.
By their numbers in this assay, from the lowest: compound 1; then compounds 3 and 4 (each within the scatter of the next).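

In this assay, within the data shown here, the one step at this amide-type nitrogen is a 1.0-fold higher number from compound 3 to compound 4 (0.00 log units; within the scatter), so ethyl gives way to a group of 8 heavy atoms, with two carbon rings and a hydrogen-bond acceptor, while the read-out stays within the scatter. The earlier compounds shown here offered no pair differing in one place, so they could not show this. Nothing measured here accounts for the match.

As far as these compounds go, whether an amine or a carboxylic acid on this nitrogen would leave the number as level remains open. A single step also sets no trend for this position.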